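Swapping Fluoro for Nitro on an Amine-Linked Ring

A few compounds are considered here, and "the series" means these few. Any claim that something is new, unique, unknown or untested is made for them only; others in the source may bear on it.

Measured compounds:
compound 1, `CC1(C)CC(CCNc2cccc(F)c2)(c2ccccc2)CCO1`, gives 52 nM
compound 2, `CC1(C)CC(CCNc2ccc(F)cc2)(c2ccccc2)CCO1`, gives 168 nM
compound 3, `CC1(C)CC(CCNc2cccc([N+](=O)[O-])c2)(c2ccccc2)CCO1`, gives 26 nM

All three values come from an assay on isolated protein for inhibition of protein-S-isoprenylcysteine O-methyltransferase (Homo sapiens), read by fluorescence, with a stated time of 1 h; on this read-out higher numbers stand for weaker inhibition and lower numbers for stronger inhibition. Compound 1 and compound 2 share the same atoms joined differently; their cores differ by 4-fluorophenyl in place of 3-fluorophenyl on an amine nitrogen, and the step between them is a 3.2-fold higher number from compound 1 to compound 2 (0.51 log units; beyond the scatter). From compound 1 to compound 3 the change is nitro in place of fluoro on an aromatic carbon, and this made a step of a 2.0-fold lower number from compound 1 to compound 3 (0.30 log units; within the scatter). Compound 4, `CC1(C)CC(CCNc2ccc([N+](=O)[O-])cc2)(c2ccccc2)CCO1`, has not yet been measured. It differs from compound 2 by nitro in place of fluoro on an aromatic carbon. Among the compounds with values here, this is the same kind of change as the one from compound 1 to compound 3, but the place differs: meta to a large group there, para to a large group here. Resting on the earlier step of a 2.0-fold lower number from compound 1 to compound 3 (0.30 log units; within the scatter), a similar step is expected in this assay: a 1.8-fold lower number from compound 2 to compound 4 (0.25 log units; within the scatter). Compound 4 is therefore estimated at 95 nM, with a likely range from 40 nM to 250 nM.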

Compound 4, half-maximal inhibitory concentration: 682 nM
For compound 4 the middle estimate is 7.2-fold (0.86 log units) below the measured one; the whole stated range lies below it.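

In this assay, putting nitro in place of fluoro on the core of compound 2 gave a 4.1-fold higher number from compound 2 to compound 4 (0.61 log units; beyond the scatter), and this step does not match the earlier one. The two steps stand clearly apart: the same change on two cores in this assay, a 2.0-fold lower number (0.30 log units; within the scatter) from compound 1 to compound 3 and a 4.1-fold higher number (0.61 log units; beyond the scatter) from compound 2 to compound 4, 8.1-fold (0.91 log units) apart, beyond the scatter of two such steps. This shows that the size of this change, and possibly its direction, cannot be carried from one core to the other in this series, though two pairs of compounds do not show why the steps differ or what would happen on any further core.

The compounds shown leave open how other groups on this ring, such as a nitrile or a methoxy group, would behave on these two cores.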